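Methoxy in Place of Fluoro: Compound 2 to Compound 3

A few compounds are considered here, and "the series" means these few. Any claim that something is new, unique, unknown or untested is made for them only; others in the source may bear on it.

Going by the values given here, compound 2 `Cc1ccc(-c2ccc(F)cc2)n1-c1ccc(-c2nc3ccc(F)cc3s2)cc1` holds the lower of the two numbers so far in a functional assay on MCF7 cells (Homo sapiens) for cytotoxicity, read by sulforhodamine B assay, with a stated time of 48 h (a lower number here means a stronger inhibitor of growth, a higher number a weaker inhibitor of growth), where compound 2 gives 1790 nM. Compound 1 `COc1ccc(-c2ccc(C)n2-c2ccc(-c3nc4ccccc4s3)cc2)cc1` gives 2780 nM in this assay, a number within the scatter of that of compound 2, so neither can be called the stronger. Compound 3 `COc1ccc(-c2ccc(C)n2-c2ccc(-c3nc4ccc(F)cc4s3)cc2)cc1` is not yet measured; it differs from compound 2 by methoxy in place of fluoro on an aromatic carbon. Because compound 1 with that methoxy gives 2780 nM, the expected step is a 1.2-fold higher number from compound 2 to compound 3 (0.09 log units; within the scatter), nothing beyond the scatter. Compound 3 is therefore estimated at 2200 nM, with a range from 900 nM to 5500 nM.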

Compound 3, concentration for 50% growth inhibition: 2120 nM
The estimate for compound 3 lay 1.0-fold (0.02 log units) above the measured number; the measured number falls inside the stated range.
By their numbers in this assay, from the lowest: compounds 2, 3 and 1 (each within the scatter of the next).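

Going by these compounds alone, with the 4-fluorophenyl changed to 4-methoxyphenyl, the result is a 1.2-fold higher number from compound 2 to compound 3 (0.07 log units; within the scatter) in this assay, the first direct reading of this change at this position. With the methoxy kept, fluoro in place of hydrogen on an aromatic carbon gives a 1.3-fold lower number from compound 1 to compound 3 (0.12 log units; within the scatter), so neither single change separates from the scatter. Fluoro and methoxy at this position therefore cannot be told apart here, and no measurement offers an explanation for these numbers. On these data alone, whether an amine or a carboxylic acid at this position would give a step beyond the scatter remains open.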